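This account rests on a few compounds, and the source may have more. Where it says the series, first, only, none or still open, it means among the compounds named here.

Of the compounds shown here, three built on the same core have been measured in a physicochemical assay for lipophilicity, at pH 7.4; a lower number here means a more polar compound, a higher number a more lipophilic compound. Compound 1 `CCc1ccc2c(c1)CC(C)CN2S(=O)(=O)c1ccc2c(c1)C(=O)CC(C1CCOCC1)O2` gives 3.77, compound 3 `Cc1ccc(N(C2CCC2)S(=O)(=O)c2ccc3c(c2)C(=O)CC(C2CCOCC2)O3)c(C)c1` gives 3.86, and compound 2 `CC(C)CN(c1ccc(C(C)(C)C)cc1)S(=O)(=O)c1ccc2c(c1)C(=O)CC(C1CCOCC1)O2` gives 4.97. Compound 2 stands highest of the three: the gap to its nearest neighbour, compound 3, lies beyond the scatter, and the gap to compound 1, the furthest of the three, lies beyond it as well.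

Compound 4 `CC(C)CN(c1ccccc1F)S(=O)(=O)c1ccc2c(c1)C(=O)CC(C1CCOCC1)O2` has not yet been measured. It differs from compound 2 in one place: 2-fluorophenyl in place of 4-(tert-butyl)phenyl on a sulfonamide nitrogen. For the measured compounds named here, no measured pair among the three isolates this change, so nothing measured shows its size directly. Since the group that leaves counts 10 heavy atoms and the one that enters counts 7, the step from compound 2 to compound 4 is expected to be a drop well beyond the scatter, estimated at a number 1.47 log units lower from compound 2 to compound 4 (beyond the scatter). Compound 4 is therefore expected to give about 3.5 in this assay, with a likely range from 3 to 4.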

Compound 4, distribution coefficient: 3.44
The estimate for compound 4 lay 0.06 log units above the measured number; measured number inside the range.
By their numbers in this assay, from the lowest: compound 4; then compounds 1 and 3 (each within the scatter of the next); then compound 2.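

For the compounds shown here, compound 4 gives the first reading of a single change at this position: in this assay, 2-fluorophenyl in place of 4-(tert-butyl)phenyl on the sulfonamide nitrogen amounts to a number 1.53 log units lower from compound 2 to compound 4 (beyond the scatter), a large step beyond the scatter. The earlier compounds shown here differ from one another in more than one place, so they could not show that this one substituent on the nitrogen can move the number so far by itself. Nothing measured explains the size of the step.

The step combines the loss of the tert-butyl group with the gain of the fluorine, and the compounds shown do not separate the two; an unsubstituted phenyl at this place would. As far as these compounds go, how a ring carrying an amine or a carboxylic acid would read in this assay also remains open.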